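Nucleoside and acyclic nucleoside analogues: cytotoxicity on murine leukaemia cells

The source may report more compounds than this note shows. Statements on the series, on what has been measured and on what is new or still open speak of the compounds shown alone.

Measured compounds and values in an ADME assay on L1210/0 cells (Mus musculus) for cytotoxicity, with a stated time of 48 h; on this read-out lower numbers stand for stronger inhibition and higher numbers for weaker inhibition:
- compound 1 `COCC#Cc1cn([C@H]2C[C@H](O)[C@@H](CO)O2)c(=O)[nH]c1=O`: > 200000 nM, a limit of the assay
- compound 2 `Nc1nc(Cl)c2ncn(COCCO)c2n1`: > 200000 nM, a limit of the assay
- compound 3 `CN(C)c1nc2c(=O)[nH]c(N)nc2n1COCCO`: > 200000 nM, a limit of the assay

Compound 1 stands at the limit of this assay, and no number for it is known. The same holds for the other two compounds, as all three values sit at the limit of > 200000 nM in this assay, at which 3 of the 3 values shown sit. No value shown is a number, so no ordering among compound 1, compound 2 and compound 3 can be read from these data.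

Compound 4 `CCCC/C=C\c1cn([C@H]2C[C@H](O)[C@@H](CO)O2)c(=O)[nH]c1=O` is the next member to be measured. It differs from compound 1 in one place: hex-1-en-1-yl in place of 3-methoxyprop-1-yn-1-yl on an aromatic carbon. The change sits on the shared core of compound 1; the remainder of the structure, including the sugar-like part, is kept.

Within the data shown here, no measured step between compounds is available in this assay, so the size of the expected step rests on the structural change alone. Compound 4 is expected to remain weakly active, with the step from compound 1 estimated as a step that the limit leaves unreadable from compound 1 to compound 4, that is, none beyond the scatter. For compound 4 the estimate in this assay is 250000 nM, within a range from 40000 nM to 1500000 nM, with a high chance that only a limit is reported.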

Compound 4, half-maximal inhibitory concentration: > 200000 nM
Compound 4: no number, only a limit; the forecaster's own chance of this, stated with the estimate: 70%; the middle value does not contradict the limit.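

In this assay compound 4 gives > 200000 nM, a limit of the assay and not a number. Compound 1 also has only a limit, and the step between compound 1 and compound 4 cannot be read. The compounds shown leave open whether any change to the shared core would give a numerical value in this assay, because no value here is a number: the limit of > 200000 nM in this assay, at which 4 of the 4 values shown sit.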